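The source may report more compounds than this note shows. Statements on the series, on what has been measured and on what is new or still open speak of the compounds shown alone.

Measured compounds:
Compound 1 `CC(C)c1cc(C(C)(C)C)cc(-c2ccc(F)cc2)c1CO` in a functional assay on RKE cells for antagonist activity at Vasoactive intestinal polypeptide receptor 1 (Rattus norvegicus), read by HTRF and cAMP accumulation, with stated times of 10 min and 30 min (on this read-out lower numbers stand for stronger inhibition and higher numbers for weaker inhibition), gives 740 nM.
Compound 2 `CC(C)c1cc(C(C)(C)C)cc(-c2cccc(C(F)(F)F)c2)c1CO` in this assay gives only a limit of the assay, > 50000 nM.
Compound 3 `CC(C)c1cc(C(C)(C)C)cc(-c2cccc(C#N)c2)c1CO` in this assay likewise gives only a limit of the assay, > 50000 nM.

Among the measured compounds shown here, compound 1 is the only member of the set with a number. For the measured compounds named here, the other two sit at the limit of > 50000 nM in this assay, at which 2 of the 3 values shown sit, so no step from compound 1 to either of them can be sized. Going by the values given here, the single step with two measured ends, a step that the two limits leave unreadable from compound 2 to compound 3, is itself unreadable, both ends being limits, and it concerns an exchange of a different substituent at a different place on the phenyl ring.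

Compound 4 `CC(C)c1cc(C(C)(C)C)cc(-c2ccc(Cl)cc2)c1CO` differs from compound 1 in one place: chloro in place of fluoro on an aromatic carbon. Among the compounds with values here, no measured step bears on this exchange; the set gives no reading of how a change at this position moves the read-out. The exchange of one halogen for another on the same aromatic carbon is expected to move the read-out little. Compound 4 is therefore expected near compound 1, at an estimated 600 nM, with a range from 200 nM to 2000 nM. The step this implies, a 1.2-fold lower number from compound 1 to compound 4 (0.09 log units; within the scatter), is expected to lie within the usual scatter.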

Compound 4, half-maximal inhibitory concentration: 290 nM
Compound 4: the middle estimate sits 2.1-fold (0.32 log units) above what was measured, within the range that was stated.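

In this assay, among the compounds shown here, the exchange of chloro for fluoro gives a 2.6-fold lower number from compound 1 to compound 4 (0.41 log units; beyond the scatter) and this is the first readable step. For the compounds shown here, the earlier compounds offered no sized step, so this is the first sign that the read-out responds to the halogen at this position, and that the 4-fluorophenyl to 4-chlorophenyl change lowers the number here. Nothing at hand gives a cause for this step.

On these data alone, whether bromo, methoxy or an amine on the same aromatic carbon would lower the number further stays open. The substituents of compound 2 and compound 3 stand at a different place on the phenyl ring and both values are limits of the assay, so steps involving them cannot be read and the effect of substitution there remains undefined.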